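A few compounds are considered here, and "the series" means these few. Any claim that something is new, unique, unknown or untested is made for them only; others in the source may bear on it.

Within the data shown here, in a functional assay on HepG2 cells (Homo sapiens) for cytotoxicity, read by MTT assay, with a stated time of 24 h (on this read-out higher numbers stand for weaker inhibition and lower numbers for stronger inhibition), compound 2 (`N#Cc1ccc(S(=O)(=O)N2C/C(=C\c3cccnc3)C(=O)/C(=C/c3ccccc3F)C2)cc1`) gives 6600 nM, the higher of the two numbers so far. Among the measured compounds shown here, the only other measured compound, compound 1 (`O=C1/C(=C/c2cccnc2)CN(S(=O)(=O)c2ccc(C(F)(F)F)cc2)C/C1=C\c1ccccc1F`), gives 2400 nM. The next step leads to compound 3 (`CC(=O)Nc1ccc(S(=O)(=O)N2C/C(=C\c3cccnc3)C(=O)/C(=C/c3ccccc3F)C2)cc1`), with acetamido in place of cyano on an aromatic carbon, para to a large group: acetamido in place of cyano on an aromatic carbon. A single measured step bears on this, and it concerns the same aromatic carbon: a 2.8-fold higher number from compound 1 to compound 2 (0.44 log units; beyond the scatter), with cyano in place of trifluoromethyl, a modest change beyond the scatter. For the measured compounds named here, no measured compound carries acetamido, so that step suggests a size but no direction. A step no larger than modest is therefore expected in this assay, with its direction open. The estimated step is a 1.3-fold lower number from compound 2 to compound 3 (0.12 log units; within the scatter). For compound 3 the expected value is 5000 nM, with an estimated range of 2000 nM to 13000 nM.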

Compound 3, half-maximal inhibitory concentration: 4560 nM
For compound 3 the middle estimate is 1.1-fold (0.04 log units) above the measured one; the range from low to high includes it.
By their numbers in this assay, from the lowest: compounds 1, 3 and 2 (each within the scatter of the next, the first and the last beyond it).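

In this assay, acetamido in place of cyano gives a 1.4-fold lower number from compound 2 to compound 3 (0.16 log units; within the scatter) and acetamido in place of trifluoromethyl gives a 1.9-fold higher number from compound 1 to compound 3 (0.28 log units; within the scatter), so compound 3 lies within the scatter of both compounds, although the step between those two, a 2.8-fold higher number from compound 1 to compound 2 (0.44 log units; beyond the scatter), lies beyond it. This aromatic carbon, para to a large group, therefore takes a group of 4 heavy atoms with one hydrogen-bond donor, where cyano has 2 heavy atoms and no donor, without a step beyond the scatter from either earlier compound. Nothing available here accounts for these numbers.

The compounds shown leave open whether an amine or a carboxylic acid on this carbon would stay within this span. They also leave open whether a longer chain in place of the acetyl part of acetamido would do so.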